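Swapping the Ring Nitrogen Substituent: Expected Clearance

The compounds below may be only part of what the source reports. "The series", "measured", "known", "first", "only" and "open" are said of these compounds alone.

Measured so far in an ADME assay on microsomes from liver (Rattus norvegicus) for metabolic stability, read by LC-MS, using NADPH, with a stated time of 10 min, tested at 0.1 uM; a lower number here means slower removal, a higher number faster removal of the compound:
compound 1, `O=C(NCCCCc1ccccc1)c1cccc(C2SCC(=O)N2c2ccccn2)c1`, gives 1480 mL.min-1.g-1
compound 2, `C#Cc1cc(C(=O)NCCCCc2ccccc2)cc(C2SCC(=O)N2c2ccccc2OC)c1`, gives 2200 mL.min-1.g-1
compound 3, `O=C(NCCCCn1cccn1)c1cccc(C2SCC(=O)N2c2cc(F)ccn2)c1`, gives 1200 mL.min-1.g-1

All three compounds share a core in which an amide-type nitrogen in a five-membered ring carries an aromatic group, and all three are removed quickly in this assay. Compound 1 has the second highest of the three numbers. Its nearest neighbour is compound 3, whose number lies within the scatter of repeated measurements, and the furthest is compound 2, whose number is also within that scatter. So no compound among these can be called clearly more or less stable than another.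

Compound 4, `O=C(NCCCCc1ccccc1)c1cccc(C2SCC(=O)N2c2ccccc2F)c1`, has not yet been measured in this assay. It differs from compound 1 in one place: 2-fluorophenyl in place of pyridin-2-yl on an amide-type nitrogen in a ring. Compound 2, which also carries a carbon-only aromatic ring on that nitrogen, gives 2200 mL.min-1.g-1, a number within the scatter of compound 1, so no step beyond the scatter is expected here. The step from compound 1 to compound 4 is estimated as a 1.1-fold higher number from compound 1 to compound 4 (0.03 log units; within the scatter). Compound 4 is therefore expected to give about 1600 mL.min-1.g-1, most likely between 900 mL.min-1.g-1 and 2900 mL.min-1.g-1.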

Compound 4, intrinsic clearance in microsomes: 2950 mL.min-1.g-1
For compound 4 the middle estimate is 1.8-fold (0.27 log units) below the measured one, and the stated range ends below it.
By their numbers in this assay, from the lowest: compounds 3, 1, 2 and 4 (each within the scatter of the next, the first and the last beyond it).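

In this assay, placing 2-fluorophenyl instead of pyridin-2-yl on the amide-type nitrogen in the ring gives a 2.0-fold higher number from compound 1 to compound 4 (0.30 log units; within the scatter), so this exchange does not separate the two compounds. Among these compounds, compounds 1 and 4 are the first pair here that differ in one place, which makes this the first direct reading of a change at this position; the earlier comparisons all involved changes elsewhere in the molecule as well. No measurement shown here explains the size of this step.

The single step combines two changes, the ring nitrogen leaving and a fluorine entering, so the compounds shown cannot tell whether either would matter alone; a plain phenyl group at the same position, with the rest of compound 1 kept unchanged, would be needed to take them apart. As far as these compounds go, it also remains open whether a quite different group on this nitrogen, such as a phenyl ring carrying a carboxylic acid or an amine, would give a step beyond the scatter of repeated measurements.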